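A few compounds are considered here, and "the series" means these few. Any claim that something is new, unique, unknown or untested is made for them only; others in the source may bear on it.

Compound 1 `COc1ccc2c(c1)c(C1CC(c3ccccc3)=NN1C(=O)c1ccc(OC)nc1)cn2C` gives 1100 nM in a functional assay on HeLa cells (Homo sapiens) for inhibition, read by MTT assay, with a stated time of 48 h; on this read-out lower numbers stand for stronger inhibition of growth and higher numbers for weaker inhibition of growth; compound 2 `COc1ccc2c(c1)c(C1CC(c3ccc(Cl)cc3)=NN1C(=O)c1ccc(OC)nc1)cn2C` gives 2260 nM.

On these two numbers compound 2 stands highest, the weaker inhibitor of growth, set apart from compound 1 by a 2.1-fold higher number from compound 1 to compound 2 (0.31 log units; beyond the scatter). Compound 3 `COc1ccc2c(c1)c(C1CC(c3ccc(Br)cc3)=NN1C(=O)c1ccc(OC)nc1)cn2C` differs from compound 2 by bromo in place of chloro on an aromatic carbon. For the measured compounds named here, no measured step swaps one halogen for another; the only step, a 2.1-fold higher number from compound 1 to compound 2 (0.31 log units; beyond the scatter), concerns adding chloro, so it bears on compound 3 only loosely. Compound 3 is therefore expected to sit close to compound 2, with a 1.1-fold higher number from compound 2 to compound 3 (0.04 log units; within the scatter) not beyond the scatter. The estimate for compound 3 is 2500 nM, ranging from 1200 nM to 5500 nM.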

Compound 3, concentration for 50% growth inhibition: > 10000 nM
Compound 3: a limit, no number (the forecaster's own chance of this, stated with the estimate: 2%); middle value at least 4.0-fold (0.60 log units) away from the limit.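

Compound 3 carries a limit, not a number: the limit of > 10000 nM in this assay, at which 1 of the 3 values shown sits. Exchanging one halogen for another on this aromatic carbon, para to a large group, is therefore not a neutral swap: it gives an at least 4.4-fold higher number from compound 2 to compound 3 (0.64 log units; beyond the scatter), while replacing the original hydrogen with bromo gives an at least 9.0-fold higher number from compound 1 to compound 3 (0.95 log units; beyond the scatter). Growth inhibition here depends on which halogen is present, not merely on whether one is present.

On these data alone, how far compound 3 lies past its limit remains unknown. Also open, as far as these compounds go, is how fluoro, methoxy or an amine at this position would compare with hydrogen.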